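Acyl versus triazinyl groups on the amine nitrogen

The source may hold more compounds than are shown below. What is called first, only, known or untested is meant among the compounds shown, and "the series" means these compounds.

- Compound 1 `CCCCOC(=O)CNC(=O)[C@H](CSc1ccc([N+](=O)[O-])cc1[N+](=O)[O-])NC(=O)CC[C@H](NC(=O)c1ccccc1)C(=O)OCCCC`: > 300 uM
- Compound 2 `CCCCOC(=O)CNC(=O)[C@H](CSc1ccc([N+](=O)[O-])cc1[N+](=O)[O-])NC(=O)CC[C@H](NC(=O)C(C)(C)C)C(=O)OCCCC`: 83.4 uM
- Compound 3 `CCCCOC(=O)CNC(=O)[C@H](CSc1ccc([N+](=O)[O-])cc1[N+](=O)[O-])NC(=O)CC[C@H](Nc1nc(N)nc(Cl)n1)C(=O)OCCCC`: > 300 uM
- Compound 4 `CCCCOC(=O)CNC(=O)[C@H](CSc1ccc([N+](=O)[O-])cc1[N+](=O)[O-])NC(=O)CC[C@H](NC(=O)COc1ccccc1)C(=O)OCCCC`: not yet measured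

In a toxicity assay on KB cells (Homo sapiens) for cytotoxicity, read by fluorescence, with a stated time of 3 days (a lower number here means that less compound is needed, a higher number that more compound is needed for the effect), compound 3 gives > 300 uM, which is a limit and not a number. Compound 1 also sits at a limit, > 300 uM. This is the limit of > 300 uM in this assay, at which 2 of the 3 values shown sit. Only compound 2 gives a number, 83.4 uM.

Compound 4 differs from compound 3 as follows: (phenoxymethyl)carbonyl in place of 4-amino-6-chloro-1,3,5-triazin-2-yl on an amine nitrogen. An acyl group thus returns to the amine nitrogen, as in compound 1 and compound 2. Among the measured compounds shown here, two steps bear on this: an at least 3.5-fold higher number from compound 2 to compound 3 (0.55 log units; beyond the scatter), and an at least 3.5-fold lower number from compound 1 to compound 2 (0.55 log units; beyond the scatter). The third, a step that the two limits leave unreadable from compound 1 to compound 3, cannot be read. Compound 1 shows that an acyl group alone need not leave the limit, so only a modest move to a lower number is expected. The expected change is an at least 2.0-fold lower number from compound 3 to compound 4 (0.30 log units; that floor lies within the scatter). The estimate for compound 4 is 150 uM, with an expected range of 60 uM to 300 uM.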

Compound 4, concentration for half-maximal effect: > 300 uM
Compound 4 was reported as a limit (the forecaster's own chance of this, stated with the estimate: 35%); middle value at least 2.0-fold (0.30 log units) from the limit.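

In this assay, phenoxymethyl in place of tert-butyl on a carbonyl carbon gives an at least 3.5-fold higher number from compound 2 to compound 4 (0.55 log units; beyond the scatter), so a second aromatic acyl group fails to reproduce the number of compound 2. Compound 4 gives > 300 uM, a limit and not a number, and its steps to compound 1 and compound 3 cannot be read. Among the groups shown on the amine nitrogen, only the (tert-butyl)carbonyl of compound 2 leaves the limit: the limit of > 300 uM in this assay, at which 3 of the 4 values shown sit.

On these data alone, whether that number needs tert-butyl specifically or merely the lack of an aromatic ring stays open. An isopropyl or cyclohexyl group on the carbonyl carbon would separate these two readings.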